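Urea-to-amide swap on the shared core and expected growth inhibition

The source may hold more compounds than are shown below. What is called first, only, known or untested is meant among the compounds shown, and "the series" means these compounds.

Measured compounds:
Compound 1, `COc1cc(-c2nn(-c3cccc(NC(=O)Nc4cc(C(F)(F)F)cc(C(F)(F)F)c4)c3)cc2-c2ccncc2)ccc1Cl`, 3970 nM in a functional assay on SR cells (Homo sapiens) for inhibition, read by sulforhodamine B assay, with a stated time of 48 h; on this read-out lower numbers stand for stronger inhibition of growth and higher numbers for weaker inhibition of growth.
Compound 2, `COc1cc(-c2nn(-c3cccc(NC(=O)Nc4ccc(Cl)c(Cl)c4)c3)cc2-c2ccncc2)ccc1Cl`, 2800 nM.
Compound 3, `O=C(Nc1cccc(-n2cc(-c3ccncc3)c(-c3ccc(Cl)c(O)c3)n2)c1)Nc1ccc(Cl)c(Cl)c1`, 15000 nM.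

Compound 2 gives the lowest number of the three; compound 1 lies within the scatter of it, while compound 3 is set apart by a 5.4-fold higher number from compound 2 to compound 3 (0.73 log units; beyond the scatter). Compound 4, `COc1cc(-c2nn(-c3cccc(NC(=O)c4ccccc4)c3)cc2-c2ccncc2)ccc1Cl`, differs from compound 2 by phenyl in place of (3,4-dichlorophenyl)amino on a carbonyl carbon. No measured step touches this part of the molecule: the one shown step concerns the oxygen on the other ring, and compounds 1 and 2 only show that two different substituted rings on the urea give numbers within the scatter. Without a guiding step, a weaker inhibition is expected for compound 4, a rise of a 2.9-fold higher number from compound 2 to compound 4 (0.46 log units; beyond the scatter), giving an estimated 8000 nM within 2500 nM to 25000 nM.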

Compound 4, concentration for total growth inhibition: > 100000 nM
Compound 4 was reported as a limit; the forecaster's own chance of this, stated with the estimate: 10%; middle value at least 12-fold (1.09 log units) from the limit.
By their numbers in this assay, from the lowest: compounds 2 and 1 (each within the scatter of the next); then compound 3. At a limit, above all of these: compound 4.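

Exchanging (3,4-dichlorophenyl)amino for phenyl on the carbonyl carbon turns the urea into a benzamido group and gives an at least 35-fold higher number from compound 2 to compound 4 (1.55 log units; beyond the scatter) in this assay. The value for compound 4 is a limit: the limit of > 100000 nM in this assay, at which 1 of the 4 values shown sits.

Compounds 1 and 2, with different rings on the urea, had stayed within the scatter of each other, whereas this change shows that growth inhibition here can be lost to a far greater extent.

This one change removes both the amino nitrogen and the chlorines, and the compounds shown cannot separate the two. Phenylamino or 3,4-dichlorophenyl on the carbonyl carbon would address that question.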